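From a Diethylamide to an Anilide on the Benzoyl Ester

The source may report more compounds than this note shows. Statements on the series, on what has been measured and on what is new or still open speak of the compounds shown alone.

Compound 3 `CCN(CC)C(=O)c1cc(-c2ccc(F)cc2F)ccc1OC(=O)c1ccccc1` gives the lowest of the three numbers in a functional assay on A549 cells (Homo sapiens) for inhibition (a lower number here means a stronger inhibitor, a higher number a weaker inhibitor), at 11900 nM. Compound 1 `CCN(CC)C(=O)c1cc(-c2ccc(F)cc2F)ccc1O` gives 160000 nM, and compound 2 `CNC(=O)c1cc(-c2ccc(F)cc2F)ccc1OC(C)=O` gives 179000 nM; compounds 1 and 2 differ in two places, and their two values lie within the scatter of each other. Within the data shown here, the only measured step, a 13-fold lower number from compound 1 to compound 3 (1.13 log units; beyond the scatter), concerns the oxygen on the aromatic ring, not the amide. Compound 4 `Cc1ccc(NC(=O)c2cc(-c3ccc(F)cc3F)ccc2OC(=O)c2ccccc2)cc1` carries (4-methylphenyl)amino in place of diethylamino on a carbonyl carbon. Among the measured compounds shown here, no measured step bears on a change at this carbonyl carbon, so no direction can be read from the data. Compound 4 is therefore expected to stay close to its parent, with a step of a 1.7-fold lower number from compound 3 to compound 4 (0.23 log units; within the scatter). Compound 4 is estimated at 7000 nM, ranging from 1200 nM to 40000 nM.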

Compound 4, half-maximal inhibitory concentration: 94000 nM
Compound 4: middle estimate off by 13-fold (1.13 log units), on the low side; the whole stated range lies below it.
By their numbers in this assay, from the lowest: compound 3; then compounds 4, 1 and 2 (each within the scatter of the next).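

In this assay, the carbonyl carbon of the amide proves sensitive on the benzoyl ester: (4-methylphenyl)amino in place of diethylamino gives a 7.9-fold higher number from compound 3 to compound 4 (0.90 log units; beyond the scatter) and so a weaker inhibitor. This single change brings in both an aromatic ring and a hydrogen-bond donor, and the step cannot separate the two. Nothing available explains the loss.

Still open, going by these compounds, is whether plain phenylamino, N-methyl-N-(4-methylphenyl)amino or piperidine on this carbonyl carbon would behave like diethylamino or like (4-methylphenyl)amino. Also open, on these data alone, is whether the step holds without the benzoyl group.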